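Alkyl Thioureas on a Shared Core: Cytotoxicity Outlook

The source may report more compounds than this note shows. Statements on the series, on what has been measured and on what is new or still open speak of the compounds shown alone.

Compound 1 `COc1cccc(NC(=S)Nc2cccc(C(F)(F)F)c2)c1` — 26000 nM
Compound 2 `CCNC(=S)Nc1cccc(C(F)(F)F)c1` — > 100000 nM, a limit of the assay, not a number
Compound 3 `O=C(NC(=S)Nc1cccc(C(F)(F)F)c1)[C@H]1C[C@@H]2CC[C@H]1C2` — 42000 nM

In an ADME assay on MT4 cells (Homo sapiens) for cytotoxicity (a higher number here means that more compound is tolerated, a lower number that less compound is tolerated), compound 1 gives 26000 nM and compound 3 gives 42000 nM. Compound 2 reaches only > 100000 nM, which is a limit of this assay rather than a measured number. Compound 2 therefore stands at the limit of > 100000 nM in this assay, at which 1 of the 3 values shown sits, the sole one of the three at that position. Compound 4 `CSCCCNC(=S)Nc1cccc(C(F)(F)F)c1` differs from compound 2 by (methylsulfanyl)methyl in place of hydrogen on a saturated chain carbon, two bonds along the chain from an amide-type nitrogen. Among the compounds with values here, no step between two measured compounds has been recorded, so the expectation rests on the three values alone. The step from compound 2 to compound 4 in this assay is expected to be small, about an at least 1.4-fold lower number from compound 2 to compound 4 (0.15 log units; that floor lies within the scatter), toward less compound tolerated. Compound 4 is thus expected to give about 70000 nM, within 25000 nM to 200000 nM.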

Compound 4, half-maximal cytotoxic concentration: 43000 nM
Compound 4: middle estimate off by 1.6-fold (0.21 log units), on the high side, and the stated range covers the measured number.
By their numbers in this assay, from the lowest: compounds 1, 3 and 4 (each within the scatter of the next). At a limit, above all of these: compound 2.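

Compound 2 stands at a limit rather than a number: the limit of > 100000 nM in this assay, at which 1 of the 4 values shown sits. In this assay, the change from ethyl to 3-(methylsulfanyl)propyl gives an at least 2.3-fold lower number from compound 2 to compound 4 (0.36 log units; beyond the scatter), so this saturated chain carbon is not indifferent to the change. Going by these compounds, because compound 2 is only a limit, the printed step is a floor and its full size remains unknown.

The compounds shown leave open whether the sulfur or the added chain length carries this step. A plain pentyl chain or a terminal amine at this place would help to separate the two.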